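This account rests on a few compounds, and the source may have more. Where it says the series, first, only, none or still open, it means among the compounds named here.

In a functional assay on T-24 cells (Homo sapiens) for antiproliferative activity, read by MTT assay, with a stated time of 48 h (on this read-out higher numbers stand for weaker inhibition and lower numbers for stronger inhibition), compound 1 `O=C(Nc1ccc(Cl)cc1)Nc1cccc(CNc2nccnc2Cl)c1` gives 5470 nM. Among the three measured compounds it stands second highest, and neither neighbour is separated from it by more than the scatter: compound 2 `O=C(Nc1cccc(CNc2nccnc2Cl)c1)Nc1ccc(F)c(Cl)c1` gives 4990 nM in this assay, and compound 3 `Cc1ccc(NC(=O)Nc2cccc(CNc3nccnc3Cl)c2)cc1` gives 9820 nM. The steps between them are a 1.1-fold lower number from compound 1 to compound 2 (0.04 log units; within the scatter), a 1.8-fold higher number from compound 1 to compound 3 (0.25 log units; within the scatter) and a 2.0-fold higher number from compound 2 to compound 3 (0.29 log units; within the scatter), all within the scatter.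

Compound 4 `O=C(Nc1cccc(CNc2nccnc2Cl)c1)Nc1ccc(Cl)c(Cl)c1` differs from compound 1 by chloro in place of hydrogen on an aromatic carbon. The step that bears most directly on this is a 1.1-fold lower number from compound 1 to compound 2 (0.04 log units; within the scatter), which also brings a chloro onto the 4-chlorophenyl ring, though together with a change of the chloro to fluoro; it left the number essentially unchanged. The other two steps likewise show that the aryl group on the urea has had little effect in this set. Compound 4 is therefore expected to show a 1.1-fold lower number from compound 1 to compound 4 (0.04 log units; within the scatter), that is, no step beyond the scatter. Compound 4 is estimated at 5000 nM in this assay, with a range from 2500 nM to 10000 nM.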

Compound 4, half-maximal inhibitory concentration: 5210 nM
Compound 4: middle estimate off by 1.0-fold (0.02 log units), on the low side, within the range that was stated.
By their numbers in this assay, from the lowest: compounds 2, 4, 1 and 3 (each within the scatter of the next).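

Chloro in place of hydrogen on the aromatic carbon, ortho to a chloro group, turns 4-chlorophenyl into 3,4-dichlorophenyl and gives the first reading of this single change in this assay (a 1.0-fold lower number from compound 1 to compound 4 (0.02 log units; within the scatter)). Chloro in place of fluoro (a 1.0-fold higher number from compound 2 to compound 4 (0.02 log units; within the scatter)) and 3,4-dichlorophenyl in place of 4-methylphenyl (a 1.9-fold lower number from compound 3 to compound 4 (0.28 log units; within the scatter)) also stay within the scatter, so among these four compounds no change on this aryl ring yet separates one number from another. Nothing measured here accounts for how close these numbers lie.

From the compounds shown here alone, whether a methoxy group, an amine or a carboxylic acid at this position would move the number beyond the scatter stays open. Also open, going by these compounds, is what replacing the chloro on the shared core with an amine would do in this assay.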